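A few compounds are considered here, and "the series" means these few. Any claim that something is new, unique, unknown or untested is made for them only; others in the source may bear on it.

The compounds here share one core and differ in the group carried on an amine nitrogen. In a functional assay on HeLa cells (Homo sapiens) for antiproliferative activity, read by CCK-8 assay, with a stated time of 48 h (a lower number here means a stronger inhibitor, a higher number a weaker inhibitor), compound 2 (`COc1ccc(/C=C\c2cc(OC)c(OC)c(OC)c2)cc1OCc1ccc(CN[C@H](C(=O)O)[C@H](C)O)cc1`) reads > 10000 nM, which is a limit of the assay and not a number. Compound 4 (`COc1ccc(/C=C\c2cc(OC)c(OC)c(OC)c2)cc1OCc1ccc(CNCCNC(C)=O)cc1`) is still unmeasured, and it carries 2-acetamidoethyl in place of 1-carboxy-2-hydroxypropyl (2-acetamidoethyl in place of 1-carboxy-2-hydroxypropyl on an amine nitrogen), so the carboxy group leaves. For the measured compounds named here, two measured steps bear on this. Compound 1 (`COc1ccc(/C=C\c2cc(OC)c(OC)c(OC)c2)cc1OCc1ccc(CN2CCCCC2C(=O)O)cc1`) also has a carboxy group and gives 14200 nM, while compound 3 (`COc1ccc(/C=C\c2cc(OC)c(OC)c(OC)c2)cc1OCc1ccc(CNCCO)cc1`) has none and gives 4400 nM. The closest parallel is an at least 2.2-fold lower number from compound 2 to compound 3 (0.35 log units; beyond the scatter), which is the same kind of exchange on the same nitrogen. The other is a 3.2-fold lower number from compound 1 to compound 3 (0.51 log units; beyond the scatter). Going by the values given here, in both, losing the carboxy group goes with a lower number, and no compound here goes against that. The same direction is therefore expected, and the expected size is modest: an at least 2.5-fold lower number from compound 2 to compound 4 (0.39 log units; beyond the scatter). For compound 4 the estimated value is 4000 nM, with an expected range from 1200 nM to 14000 nM.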

Compound 4, half-maximal inhibitory concentration: 6400 nM
The estimate for compound 4 lay 1.6-fold (0.20 log units) below the measured number; low and high end bracket the measured number.
By their numbers in this assay, from the lowest: compounds 3 and 4 (each within the scatter of the next); then compound 1.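

In this assay, the step for this exchange on the amine nitrogen is an at least 1.5-fold lower number from compound 2 to compound 4 (0.19 log units; that floor lies within the scatter), and that is only a floor, since compound 2 stands at a limit of the assay and not at a number: the limit of > 10000 nM in this assay, at which 1 of the 4 values shown sits.

Acetamido in place of hydroxy, two bonds along the chain from the amine nitrogen, gives a 1.5-fold higher number from compound 3 to compound 4 (0.16 log units; within the scatter), so these two groups without a carboxy cannot be told apart here. Against the piperidine-bearing acid the difference is readable, a 2.2-fold lower number from compound 1 to compound 4 (0.35 log units; beyond the scatter), so a second group without a carboxy now goes with a lower number, and no compound shown goes against this.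

Open, on these data alone, is whether a 2-aminoethyl group or a longer chain carrying acetamido would move the number beyond the scatter. Also open, as far as these compounds go, is how a carboxylic acid on a chain without the hydroxy would read, which would separate the carboxy group from the rest of the group that leaves.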